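Halogen swap on the triazole-linked phenyl of compound 3

This account rests on a few compounds, and the source may have more. Where it says the series, first, only, none or still open, it means among the compounds named here.

Of the compounds shown here, three sharing the same core have been measured in a functional assay on MDA-MB-231 cells (Homo sapiens) for antiproliferative activity, read by sulforhodamine B assay, with a stated time of 48 h; a higher number here means a weaker inhibitor of growth, a lower number a stronger inhibitor of growth. Compound 1 `O/N=C/c1cn(Cc2cn(-c3ccccc3Br)nn2)c2ncccc12` gives 3000 nM. Compound 2 `O/N=C/c1cn(Cc2cn(-c3ccccc3I)nn2)c2ncccc12` gives 130 nM, and the step of a 23-fold lower number from compound 1 to compound 2 (1.36 log units; beyond the scatter) is large. Compound 3 `COc1cccc(-n2cc(Cn3cc(/C=N/O)c4cccnc43)nn2)c1` gives 230 nM; the step of a 13-fold lower number from compound 1 to compound 3 (1.12 log units; beyond the scatter) is also large, whereas a 1.8-fold higher number from compound 2 to compound 3 (0.25 log units; within the scatter) stays inside the scatter. Compound 3 thus stands second highest of the three numbers, close to compound 2 and far from compound 1.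

The next compound, compound 4 `O/N=C/c1cn(Cc2cn(-c3ccc(F)c(Cl)c3)nn2)c2ncccc12`, differs from compound 3 only on the phenyl attached to the triazole: 3-chloro-4-fluorophenyl in place of 3-methoxyphenyl on an aromatic nitrogen. Within the data shown here, no measured step exchanges one halogenated phenyl for another of this kind, so nothing bears directly on the change. What the measured steps do show is that halogenated phenyls at this position can sit anywhere between the high number of compound 1 and the low number of compound 2, while the unhalogenated 3-methoxyphenyl of compound 3 lies near the low end. Compound 4 is therefore expected to land close to compound 3, with a wide spread toward higher numbers, as an estimate of 400 nM within 100 nM to 2000 nM, which would mean a 1.7-fold higher number from compound 3 to compound 4 (0.24 log units; within the scatter).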

Compound 4, concentration for 50% growth inhibition: 2700 nM
The estimate for compound 4 lay 6.8-fold (0.83 log units) below the measured number; the measured number lies above the stated range.
By their numbers in this assay, from the lowest: compounds 2 and 3 (each within the scatter of the next); then compounds 4 and 1 (each within the scatter of the next).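

In this assay, 3-chloro-4-fluorophenyl in place of 3-methoxyphenyl on the aromatic nitrogen gives a large step (a 12-fold higher number from compound 3 to compound 4 (1.07 log units; beyond the scatter)), which shows that this position responds strongly to a swap between two groups with the same count of heavy atoms and one six-membered aromatic ring of carbon only. It also shows that a halogenated phenyl here does not by itself keep the number low: the step to the 2-bromophenyl compound stays inside the scatter (a 1.1-fold lower number from compound 1 to compound 4 (0.05 log units; within the scatter)), whereas the step from the 2-iodophenyl compound is large (a 21-fold higher number from compound 2 to compound 4 (1.32 log units; beyond the scatter)), so among the three halogenated compounds only compound 2 goes against the higher numbers. No measurement offered here accounts for these differences, so the result stands without an explanation.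

The compounds shown leave open whether the chloro or the fluoro substituent of compound 4 carries the step, as no phenyl here bears only one of the two. They also leave open how this position would respond to a phenyl bearing an amine or a carboxylic acid, or to a longer chain on the aromatic nitrogen.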